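A few compounds are considered here, and "the series" means these few. Any claim that something is new, unique, unknown or untested is made for them only; others in the source may bear on it.

Compound 1 `O=S(=O)(/C=C/c1ccccc1Cl)Nc1ccccc1` carries a sulfonamide linking an unsubstituted phenyl ring to a chlorinated styryl group. In an assay on U2OS cells for activation of nuclear factor erythroid 2-related factor 2 (Homo sapiens), read by chemiluminescence, with a stated time of 6 h (on this read-out lower numbers stand for an effect already at smaller amounts and higher numbers for an effect only at larger amounts of compound), compound 1 gives > 10000 nM, which is a limit of the assay and not a measured number. Compound 1 therefore stands at the limit of > 10000 nM in this assay, at which 1 of the 2 values shown sits, so its true value is known only as being past that boundary. Compound 2 `COc1ccccc1NS(=O)(=O)/C=C/c1ccccc1Cl` differs from compound 1 by a methoxy in place of hydrogen on an aromatic carbon, and in this assay compound 2 gives 6350 nM. Within the data shown here, the step of an at least 1.5-fold lower number from compound 1 to compound 2 (0.19 log units; that floor lies within the scatter) is the only measured change on the phenyl ring, and its floor lies within the usual scatter, so it offers only weak guidance.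

Compound 3 `COc1cccc(NS(=O)(=O)/C=C/c2ccccc2Cl)c1` is not yet measured. It differs from compound 1 by methoxy in place of hydrogen on an aromatic carbon, placed on an aromatic carbon of the six-membered carbon ring, meta to a large group. Among the measured compounds shown here, since the one related step is small, a step of an at least 1.2-fold lower number from compound 1 to compound 3 (0.09 log units; that floor lies within the scatter) is expected, with a fair chance that only a limit is reported. The estimate for compound 3 in this assay is 8000 nM, with a range from 3000 nM to 20000 nM.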

Compound 3, half-maximal effective concentration: > 10000 nM
Compound 3 gave a limit, no number; the forecaster's own chance of this, stated with the estimate: 45%; at least 1.2-fold (0.09 log units) between middle value and limit.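

In this assay, compound 1 and compound 3 are both reported only as a limit, not a number, so no step can be read between them: the limit of > 10000 nM in this assay, at which 2 of the 3 values shown sit. The compounds shown leave open how far past that limit each one truly lies, and so whether methoxy in place of hydrogen, meta to a large group, changes the read-out at all.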